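Removing a Bromine from an Inactive Kinase Inhibitor

The source may report more compounds than this note shows. Statements on the series, on what has been measured and on what is new or still open speak of the compounds shown alone.

In an in vitro assay on Sf9 cells for inhibition of RAC-alpha serine/threonine-protein kinase (Homo sapiens), read by AlphaScreen, with a stated time of 20 min (on this read-out lower numbers stand for stronger inhibition and higher numbers for weaker inhibition), compound 1 `Nc1ncccc1-c1nc2cccnc2n1-c1ccc(NC(=O)c2ccccc2)cc1` gives 14 nM. Compound 2 `CC(C)(C)c1ccc(-n2c(-c3cccnc3N)nc3cc(Br)cnc32)cc1` stands apart: in this assay it reaches only the limit > 300000 nM, so no number is known for it. Compound 3 `COc1ccccc1Cn1c(-c2cccnc2N)nc2cc(Br)cnc21` also reaches only the limit > 300000 nM in this assay. Two of the three values are therefore limits rather than numbers (the limit of > 300000 nM in this assay, at which 2 of the 3 values shown sit). Compound 4 `CC(C)(C)c1ccc(-n2c(-c3cccnc3N)nc3cccnc32)cc1` is compound 2 with hydrogen in place of bromo on an aromatic carbon. Among the measured compounds shown here, no step between measured compounds can be computed here; compound 1, which carries the same core without a bromo, gives 14 nM. Compound 2 and compound 3, the two compounds bearing the bromo, each sit at a limit. Removing the bromo is expected to be a large step toward stronger inhibition, an at least 150-fold lower number from compound 2 to compound 4 (2.17 log units; beyond the scatter). Compound 4 is expected to give about 2000 nM, within 100 nM to 100000 nM.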

Compound 4, half-maximal inhibitory concentration: 3900 nM
Compound 4: the middle estimate sits 2.0-fold (0.29 log units) below what was measured; low and high end bracket the measured number.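

Compound 2 is known only as a limit, > 300000 nM, so the step from it is a minimum. In this assay, hydrogen in place of bromo on this aromatic carbon gives an at least 76-fold lower number from compound 2 to compound 4 (1.88 log units; beyond the scatter), showing that inhibition at this position depends strongly on this single change. Removing the bromo does not close the whole gap, as tert-butyl in place of benzamido gives a 280-fold higher number from compound 1 to compound 4 (2.44 log units; beyond the scatter).

From the compounds shown here alone, whether a smaller atom such as fluorine, or a methyl group, would be tolerated on this carbon remains open. So does whether compound 3 would also gain from losing its bromo.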